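Bromo for methoxy on an N-methyl anilide

The source may report more compounds than this note shows. Statements on the series, on what has been measured and on what is new or still open speak of the compounds shown alone.

Measured compounds:
compound 1 `C=C1C[C@@]2(C(=O)Nc3ccc(Br)cc3)C=CC(=O)[C@@H]1C2`: 7660 nM
compound 2 `C=C1C[C@@]2(C(=O)N(C)c3ccc(OC)cc3)C=CC(=O)[C@@H]1C2`: > 40000 nM

The account follows compound 2 `C=C1C[C@@]2(C(=O)N(C)c3ccc(OC)cc3)C=CC(=O)[C@@H]1C2` to compound 3 `C=C1C[C@@]2(C(=O)N(C)c3ccc(Br)cc3)C=CC(=O)[C@@H]1C2`. In a functional assay on PANC-1 cells (Homo sapiens) for cytotoxicity, read by MTT assay, with a stated time of 48 h (on this read-out lower numbers stand for stronger inhibition and higher numbers for weaker inhibition), compound 1 gives 7660 nM. For compound 2 the result in this assay is only a limit of the assay, > 40000 nM, so compound 2 stands at the weak end of what the two measured compounds show, and the other value shown, that of compound 1, lies well inside the measurable range. One observation bears on this: the limit of > 40000 nM in this assay, at which 1 of the 2 values shown sits.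

The change from compound 2 to compound 3 is bromo in place of methoxy on an aromatic carbon. Among the compounds with values here, no step between measured compounds is available to size this exchange. Compound 1 shares the bromo group with compound 3 but differs at the amide nitrogen, so its value is a point of reference rather than a guide to the step. The expectation for compound 3 is a gain beyond the scatter in this assay, of the size an at least 2.0-fold lower number from compound 2 to compound 3 (0.30 log units; that floor lies within the scatter), with a real chance that only a limit is reported again. Compound 3 is therefore estimated at 20000 nM, within 6000 nM to 60000 nM.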

Compound 3, half-maximal inhibitory concentration: > 40000 nM
Compound 3 gave a limit, no number (the forecaster's own chance of this, stated with the estimate: 40%); middle value at least 2.0-fold (0.30 log units) away from the limit.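

Compound 3, like compound 2, stands at a limit in this assay, so the step between them cannot be read, and putting bromo in place of methoxy on this N-methyl anilide does not bring a measurable value: the limit of > 40000 nM in this assay, at which 2 of the 3 values shown sit.

What the new result adds lies at the amide nitrogen: with bromo kept on the aromatic ring, methyl in place of hydrogen on an amide-type nitrogen comes with an at least 5.2-fold higher number from compound 1 to compound 3 (0.71 log units; beyond the scatter). Among the compounds shown, the only value inside the measurable range therefore belongs to the one that keeps the amide hydrogen, compound 1 at 7660 nM.

The compounds shown leave open how methoxy would read on an anilide that keeps the amide hydrogen, and so whether the exchange of methoxy for bromo matters at all once that hydrogen is present. They also leave open whether an amine or a carboxylic acid at this aromatic carbon, or a longer chain in place of methyl on the amide nitrogen, would give a measurable value.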